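Aryl amine series: one chloro fewer, prostate cell toxicity

This account rests on a few compounds, and the source may have more. Where it says the series, first, only, none or still open, it means among the compounds named here.

Measured so far in a functional assay on cells (Panel prostate (Carcinoma cell lines), Homo sapiens) for inhibition, read by sulforhodamine B assay, with a stated time of 48 h; on this read-out higher numbers stand for lower toxicity in this test and lower numbers for higher toxicity in this test:
compound 1 `CN1CCN(CCCOc2cccc3nc(Nc4ccc(Cl)c(C(F)(F)F)c4)ccc23)CC1` gives 5880 nM
compound 2 `CN1CCN(CCCOc2cccc3nc(Nc4ccc(F)c(F)c4)ccc23)CC1` gives 18000 nM
compound 3 `CN1CCN(CCCOc2cccc3nc(Nc4cc(Cl)cc(Cl)c4)ccc23)CC1` gives 5960 nM

Compound 3 stands second highest of the three numbers in this assay. Its nearest neighbour is compound 1, a 1.0-fold higher number from compound 1 to compound 3 (0.01 log units; within the scatter), a gap that tells nothing. Among the compounds with values here, the only substantial step in the set is a 3.0-fold lower number from compound 2 to compound 3 (0.48 log units; beyond the scatter), matched by a 3.1-fold higher number from compound 1 to compound 2 (0.49 log units; beyond the scatter), so the two compounds carrying a pair of heavier halogen-type groups sit together and the difluoro compound 2 apart.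

Compound 4 `CN1CCN(CCCOc2cccc3nc(Nc4cccc(Cl)c4)ccc23)CC1` is the next member. Relative to compound 3 the change is hydrogen in place of chloro on an aromatic carbon; it sits on an aromatic carbon of a six-membered aromatic ring of carbon only, meta to a chloro group, meta to a large group, and reads 3,5-dichlorophenyl to 3-chlorophenyl. Within the data shown here, no measured step removes a single substituent from this ring; the closest guidance is that exchanging the heavy pair for the light pair in a 3.1-fold higher number from compound 1 to compound 2 (0.49 log units; beyond the scatter) and a 3.0-fold lower number from compound 2 to compound 3 (0.48 log units; beyond the scatter) moved the number modestly. Taking one chloro away is expected to move compound 4 toward the lighter end, by a modest step: a 1.7-fold higher number from compound 3 to compound 4 (0.22 log units; within the scatter) is expected. The estimate for compound 4 in this assay is 10000 nM, with a range from 4500 nM to 25000 nM.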

Compound 4, concentration lethal to 50% of the cells: 7020 nM
Compound 4: middle estimate off by 1.4-fold (0.15 log units), on the high side, and the stated range covers the measured number.
By their numbers in this assay, from the lowest: compounds 1, 3 and 4 (each within the scatter of the next); then compound 2.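

Working notes on the aryl amine ring: in this assay, hydrogen in place of chloro at this position, meta to a chloro group, gives no readable change (a 1.2-fold higher number from compound 3 to compound 4 (0.07 log units; within the scatter)), so among the compounds shown the second chloro of the 3,5-dichlorophenyl group is not needed to keep the number at this level. The new compound also sits with the 4-chloro-3-(trifluoromethyl)phenyl member (a 1.2-fold higher number from compound 1 to compound 4 (0.08 log units; within the scatter)) and stays apart from the difluoro member (a 2.6-fold lower number from compound 2 to compound 4 (0.41 log units; beyond the scatter)), which shows that the earlier split does not depend on a pair of heavier substituents, since a single chloro on the ring falls on the same side. No measured data on the origin of this flat step are at hand, so the result stands as an observation only.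

Going by these compounds, it remains open whether an unsubstituted phenyl, a 3-fluorophenyl or a 3-methoxyphenyl would stay with the chloro compounds or move toward the difluoro compound 2. Also open, on these data alone, is how far this grouping would hold with a morpholine ring or a longer chain in place of the side chain shared by all four compounds.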